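The source may report more compounds than this note shows. Statements on the series, on what has been measured and on what is new or still open speak of the compounds shown alone.

Measured in an ADME assay on Caco-2 cells (Homo sapiens) for permeability, in the apical to basolateral direction; on this read-out higher numbers stand for higher permeability and lower numbers for lower permeability:
compound 1 `Cn1cncc1CN1CC(N(CC2CCN(C(=O)OC(C)(C)C)CC2)S(=O)(=O)c2ccccn2)Cc2cc(C#N)ccc21`: 15.5 10^-6 cm/s
compound 2 `CCNC(=O)N1CCC(CN(C2Cc3cc(C#N)ccc3N(Cc3cncn3C)C2)S(=O)(=O)c2ccccn2)CC1`: 0.6 10^-6 cm/s
compound 3 `Cn1cncc1CN1CC(N(CC2CCN(C(=O)C3CC3)CC2)S(=O)(=O)c2ccccn2)Cc2cc(C#N)ccc21`: 0.5 10^-6 cm/s

Compound 3 has the lowest number of the three. Against compound 2 the gap is a 1.2-fold lower number from compound 2 to compound 3 (0.08 log units; within the scatter), within the scatter, so these two are not separated. Against compound 1 the gap is a 31-fold lower number from compound 1 to compound 3 (1.49 log units; beyond the scatter); together with a 26-fold lower number from compound 1 to compound 2 (1.41 log units; beyond the scatter) this shows that the tert-butoxy group on the carbonyl carbon stands apart from both the ethylamino and the cyclopropyl group within this small set.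

Compound 4 `CC(C)S(=O)(=O)N1CCC(CN(C2Cc3cc(C#N)ccc3N(Cc3cncn3C)C2)S(=O)(=O)c2ccccn2)CC1` is not yet measured in this assay. It differs from compound 3 in one place: isopropylsulfonyl in place of cyclopropylcarbonyl on an amine nitrogen in a ring. Within the data shown here, no measured step exchanges a carbonyl for a sulfonyl at this amine nitrogen, so the new group has no direct precedent. Among the measured compounds shown here, the steps that bear on the position are a 26-fold lower number from compound 1 to compound 2 (1.41 log units; beyond the scatter) and a 31-fold lower number from compound 1 to compound 3 (1.49 log units; beyond the scatter), both large, and a 1.2-fold lower number from compound 2 to compound 3 (0.08 log units; within the scatter), within the scatter. Compound 2 and compound 3, the two without tert-butoxy, lie close together, and the isopropylsulfonyl group is taken as a third group of this kind rather than a return to the pattern of compound 1. For compound 4 a step of a 1.4-fold higher number from compound 3 to compound 4 (0.15 log units; within the scatter) is expected, within the scatter. Compound 4 is therefore estimated at 0.7 10^-6 cm/s, with a range of 0.2 10^-6 cm/s to 3 10^-6 cm/s.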

Compound 4, apparent permeability: 0.1 10^-6 cm/s
Compound 4: middle estimate off by 7.0-fold (0.85 log units), on the high side; the measured number lies below the stated range.
By their numbers in this assay, from the lowest: compound 4; then compounds 3 and 2 (each within the scatter of the next); then compound 1.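

In this assay the group on the amine nitrogen in the ring now separates compounds that lack tert-butoxy, with a 5.0-fold lower number from compound 3 to compound 4 (0.70 log units; beyond the scatter) and a 6.0-fold lower number from compound 2 to compound 4 (0.78 log units; beyond the scatter), both beyond the scatter, whereas compound 2 and compound 3 could not be told apart. Among these compounds, the low end of the series is therefore not one level shared by every replacement of tert-butoxycarbonyl: isopropylsulfonyl is the first group here to sit apart from both carbonyl-linked replacements, and the span at this position widens to a 160-fold lower number from compound 1 to compound 4 (2.19 log units; beyond the scatter). No measurement shown accounts for the lower number with isopropylsulfonyl.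

Still open, as far as these compounds go, is whether this step follows the sulfonyl link itself or the isopropyl group on it, which a cyclopropylsulfonyl group on the same nitrogen would help to separate. Also open, from the compounds shown here alone, is whether the high number of compound 1 is particular to tert-butoxycarbonyl or extends to a smaller carbamate such as ethoxycarbonyl, and where a free ring amine would fall.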